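The compounds below may be only part of what the source reports. "The series", "measured", "known", "first", "only" and "open" are said of these compounds alone.

Of the compounds shown here, three have been measured in an assay on isolated protein for inhibition of alkaline phosphatase, tissue-nonspecific isozyme (Homo sapiens); a lower number here means a stronger inhibitor, a higher number a weaker inhibitor. Compound 1, `COc1ccc(Cl)cc1S(=O)(=O)Nc1cncc(C(=O)Nc2ccccc2)c1`, gives 310 nM in this assay, the second highest of the three numbers. Compound 2, `COc1ccc(C#N)cc1S(=O)(=O)Nc1cnc2ccccc2c1`, gives 38 nM, a lower number than compound 1 by a gap beyond the usual scatter. Compound 3, `COC(=O)c1ccc(OC)c(S(=O)(=O)Nc2cccnc2)c1`, gives 1510 nM, the highest of the three. Among the compounds with values here, no two measured compounds differ in only one place, so no single step is known. Compound 4, `COc1ccc(Cl)cc1S(=O)(=O)Nc1cncc(-c2ccc(C)cc2)c1`, differs from compound 1 in one place: 4-methylphenyl in place of phenylcarbamoyl on an aromatic carbon. The step from compound 1 to compound 4 is expected to be a modest rise, a 1.9-fold higher number from compound 1 to compound 4 (0.29 log units; within the scatter), with wide uncertainty. Compound 4 is expected to give about 600 nM, within a range from 150 nM to 2500 nM.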

Compound 4, half-maximal inhibitory concentration: 147 nM
Compound 4: the middle estimate sits 4.1-fold (0.61 log units) above what was measured; the whole stated range lies above it.
By their numbers in this assay, from the lowest: compound 2; then compound 4; then compound 1; then compound 3.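

In this assay, putting 4-methylphenyl in place of phenylcarbamoyl on this aromatic carbon gives a 2.1-fold lower number from compound 1 to compound 4 (0.32 log units; beyond the scatter), a modest change. The hydrogen-bond donor and acceptor of phenylcarbamoyl are therefore not needed at this position to keep inhibition, since a group with neither still gives a lower number. Nothing available explains this shift. The compounds shown leave open how much of the step comes from the methyl and how much from losing the carbamoyl link. They also leave open how a plain phenyl, an amine or a carboxylic acid would behave here.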